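Efficacy of alkyne-linked amides at the shared core

A few compounds are considered here, and "the series" means these few. Any claim that something is new, unique, unknown or untested is made for them only; others in the source may bear on it.

Measured compounds:
compound 1, `C[C@@H](NC(=O)c1ccc(C#Cc2ccc(F)cc2F)cn1)C(C)(C)O`: 61.2%
compound 2, `C[C@@H](NC(=O)c1ccc(C#Cc2ccncc2)cn1)C(C)(C)O`: 66.6%
compound 3, `C[C@@H](NC(=O)c1ccc(C#CC2CC2)cn1)C(C)(C)O`: 63.4%

Among the compounds with values here, in a functional assay on HEK293 cells for positive allosteric modulation of metabotropic glutamate receptor 5 (Rattus norvegicus), read by fluorescence and calcium flux (a higher number here means a larger maximal response, a lower number a smaller maximal response), compound 3 sits among three numbers that lie within the usual scatter of one another; a number 2.2 percentage points higher from compound 1 to compound 3 (within the scatter) and a number 3.2 percentage points lower from compound 2 to compound 3 (within the scatter), so no compound separates from the rest. Compound 4, `C[C@@H](NC(=O)c1ccc(C#Cc2cc(F)ccn2)cn1)C(C)(C)O`, differs from compound 3 in one place: 4-fluoropyridin-2-yl in place of cyclopropyl on a triple-bonded carbon. Within the data shown here, the steps that bear on this are the two that exchange the cyclopropyl against an aromatic ring, a number 2.2 percentage points higher from compound 1 to compound 3 (within the scatter) and a number 3.2 percentage points lower from compound 2 to compound 3 (within the scatter), both within the scatter. Taking these together, no step beyond the scatter is expected in this assay for compound 4, and the estimated step is a number 0.6 percentage points higher from compound 3 to compound 4 (within the scatter). Compound 4 is therefore expected to give about 64%, within the range from 52% to 76%.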

Compound 4, largest response reached (reported as efficacy), in percent of the reference or control that the assay uses: 66.2%
Beside the measured number, compound 4's estimate is 2.2 percentage points below it, within the range that was stated.
By their numbers in this assay, from the lowest: compounds 1, 3, 4 and 2 (each within the scatter of the next).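

In this assay, within the data shown here, the new compound reads as a number 2.8 percentage points higher from compound 3 to compound 4 (within the scatter) and a number 0.4 percentage points lower from compound 2 to compound 4 (within the scatter) and a number 5 percentage points higher from compound 1 to compound 4 (within the scatter) with no step separating it from the others. At this triple-bonded carbon, then, 4-fluoropyridin-2-yl extends the level response seen so far to a ring carrying both a ring nitrogen and a fluorine, and the maximal response stays level across cyclopropyl and all three aromatic rings. No measurement is at hand that would explain this level response. On these data alone, what remains open is whether any group on this carbon can move the response beyond the scatter. An aminomethyl group or a longer alkyl chain ending in a carboxylic acid would put that to the test.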